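The source may report more compounds than this note shows. Statements on the series, on what has been measured and on what is new or still open speak of the compounds shown alone.

Values in an ADME assay on 184B5 cells (Homo sapiens) for cytotoxicity, read by MTT assay, with a stated time of 72 h; on this read-out lower numbers stand for stronger inhibition of growth and higher numbers for weaker inhibition of growth:
compound 1 `CCCOC(=O)Nc1ccc([Se]C#N)cc1`: 3700 nM
compound 2 `N#C[Se]c1ccc(NC(=O)OCc2ccccc2)cc1`: 5000 nM
compound 3 `CC(C)COC(=O)Nc1ccc([Se]C#N)cc1`: 5800 nM

The three compounds share one core and differ only in the group on the saturated chain carbon bound to an oxygen next to a carbonyl group. Compound 3 carries the largest of the three numbers, but it is not separated from the others: a 1.2-fold higher number from compound 2 to compound 3 (0.06 log units; within the scatter) and a 1.6-fold higher number from compound 1 to compound 3 (0.20 log units; within the scatter) both fall within the scatter, as does a 1.4-fold higher number from compound 1 to compound 2 (0.13 log units; within the scatter). On this evidence the three compounds read as one cluster.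

Compound 4 `CCCCCCOC(=O)Nc1ccc([Se]C#N)cc1` is not yet measured. The change from compound 3 is pentyl in place of isopropyl on a saturated chain carbon bound to an oxygen next to a carbonyl group. All three measured steps bear on it, since each alters the same place or the length of the chain there, and none moved the number beyond the scatter: ethyl to phenyl, phenyl to isopropyl and the added methyl all left the read-out essentially unchanged. A straight pentyl at this place is expected to behave likewise. The step expected here is a 1.2-fold lower number from compound 3 to compound 4 (0.06 log units; within the scatter), that is, nothing beyond the scatter in either direction. Compound 4 is accordingly estimated at 5000 nM, with a range from 2500 nM to 10000 nM.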

Compound 4, concentration for 50% growth inhibition: 4600 nM
For compound 4 the middle estimate is 1.1-fold (0.04 log units) above the measured one; the measured number falls inside the stated range.
By their numbers in this assay, from the lowest: compounds 1, 4, 2 and 3 (each within the scatter of the next).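

In this assay, the wider change from isopropyl to pentyl at the saturated chain carbon bound to an oxygen next to a carbonyl group still stays within the scatter, with a 1.3-fold lower number from compound 3 to compound 4 (0.10 log units; within the scatter). Compound 4 also sits with the phenyl of compound 2, with a 1.1-fold lower number from compound 2 to compound 4 (0.04 log units; within the scatter), and adding propyl to the chain of compound 1 gives a 1.2-fold higher number from compound 1 to compound 4 (0.09 log units; within the scatter), so the straight hexyl chain now joins the shorter propyl chain, the branched isobutyl chain and the phenyl-bearing group in one cluster, and at this place neither added length nor the swap from branched to straight separates any of the four compounds. Nothing at hand accounts for this flat read-out.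

On these data alone, whether an amine, a carboxylic acid or a chain longer than hexyl at this place would move the number beyond the scatter remains open. All four compounds share the same core, so they also say nothing about changes made anywhere else on it.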